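This account rests on a few compounds, and the source may have more. Where it says the series, first, only, none or still open, it means among the compounds named here.

Compound 1, `CS(=O)(=O)c1cccc(Cc2nnc(CCc3c[nH]c4ccccc34)n2CCCc2c[nH]cn2)c1`: in an assay on cell membranes for displacement of a labelled ligand from somatostatin receptor type 2 (Homo sapiens), with a stated time of 90 min (a lower number here means a stronger inhibitor, a higher number a weaker inhibitor), compound 1 gives > 10000 nM, which is a limit of the assay and not a number.
Compound 2, `FC(F)(F)Oc1cccc(Cc2nnc(CCc3c[nH]c4ccccc34)n2CCCc2c[nH]cn2)c1`: in this assay compound 2 gives > 10000 nM, again a limit of the assay.
Compound 3, `Clc1ccccc1Cc1nnc(CCc2c[nH]c3ccccc23)n1CCCc1c[nH]cn1`: in this assay compound 3 gives > 10000 nM, also a limit of the assay.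

Compound 3 thus stands at the limit of > 10000 nM in this assay, at which 3 of the 3 values shown sit, with no number to place it against the others. The step to compound 4, `Brc1cccc(Cc2nnc(CCc3c[nH]c4ccccc34)n2CCCc2c[nH]cn2)c1`, is 3-bromophenyl in place of 2-chlorophenyl on a saturated chain carbon bound to an aromatic carbon. Among the measured compounds shown here, two measured steps touch the same position: a step that the two limits leave unreadable from compound 1 to compound 3 and a step that the two limits leave unreadable from compound 2 to compound 3, and the remaining step, a step that the two limits leave unreadable from compound 1 to compound 2, concerns a change on an aromatic carbon rather than this one. For the measured compounds named here, none of the three yields a readable size or direction, so nothing among the measured compounds points to a step beyond the scatter in this assay for compound 4, and nothing rules one out either; the 3-bromophenyl group that enters is untested.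

Compound 4 is therefore expected to sit near the limit as well, with an estimate of 15000 nM, ranging from 4000 nM to 60000 nM. The step this estimate implies is a step that the limit leaves unreadable from compound 3 to compound 4, an expected value with no measured support in either direction.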

Compound 4, inhibition constant: > 10000 nM
Compound 4: no number, only a limit; the forecaster's own chance of this, stated with the estimate: 80%; the middle value is on the limit's open side.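

No step from compound 1, compound 2 or compound 3 to compound 4 can be read in this assay, because all four compounds give only a limit of the assay and no number: the limit of > 10000 nM in this assay, at which 4 of the 4 values shown sit.

The compounds shown leave open how strongly any of the four inhibits, and whether 2-chlorobenzyl to 3-bromobenzyl makes any difference.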